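Swapping a pyridine for fluorophenyl in a flat-lined series

The source may report more compounds than this note shows. Statements on the series, on what has been measured and on what is new or still open speak of the compounds shown alone.

Measured so far:
Compound 1, `O[C@@H](c1ccccc1)[C@H]1CO[C@H](c2ccccc2)[C@@H](C/C=C/c2ccncc2)C1` — in a functional assay on HeLa cells (Homo sapiens) for cytotoxicity, read by WST assay, with a stated time of 48 h (on this read-out lower numbers stand for stronger inhibition and higher numbers for weaker inhibition), compound 1 gives > 100000 nM, a limit of the assay rather than a number.
Compound 2, `COc1ccc(/C=C/C[C@@H]2C[C@@H]([C@@H](OC)c3ccc(OC)c(OC)c3)CO[C@H]2c2ccc(OC)c(OC)c2)cc1OC` — in this assay compound 2 gives > 100000 nM, again a limit and not a number.

Within the data shown here, compound 1 therefore stands at the edge of what this assay can report: both values shown sit at the limit of > 100000 nM in this assay, at which 2 of the 2 values shown sit, so no compound in this set has yet given a measurable number, and no step between measured compounds can be sized.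

Compound 3, `O[C@@H](c1ccccc1)[C@H]1CO[C@H](c2ccccc2)[C@@H](C/C=C/c2ccc(F)cc2)C1`, is the next compound to be measured. It differs from compound 1 in one place: 4-fluorophenyl in place of pyridin-4-yl on a double-bonded chain carbon bound to a double-bonded chain carbon. The shared core, the hydroxyl-bearing side chain and the propenyl linker all stay as they are.

Among the measured compounds shown here, with only two limits to go on, there is no measured step that points in either direction. The step is expected to be a number no higher from compound 1 to compound 3 (the limit leaves the size open), that is, none beyond the usual scatter. Compound 3 is expected to give 100000 nM, with a range from 30000 nM to 300000 nM, and most likely the assay will again report only a limit.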

Compound 3, half-maximal inhibitory concentration: 8340 nM
Estimate against measurement, compound 3: 12-fold (1.08 log units) above; the whole stated range lies above it.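

In this assay, the group at the end of the chain proves able to change the result: 4-fluorophenyl in place of pyridin-4-yl gives an at least 11-fold lower number from compound 1 to compound 3 (1.07 log units; beyond the scatter), while the shared core and the hydroxyl-bearing side chain stay as they are. Among these compounds, compound 3 gives 8340 nM, the first real number in this set, so later changes can now be sized against a measured value. The true size of the step remains unknown, and it can be stated only as a minimum because compound 1 gives a limit of the assay and not a number: the limit of > 100000 nM in this assay, at which 2 of the 3 values shown sit.

The change does two things at once, removing the ring nitrogen and adding a fluorine, so the compounds shown cannot tell which of these accounts for the step. A plain phenyl at the same place would help separate the two, and a 4-chlorophenyl or a 4-methoxyphenyl would show whether fluorine is needed there or other groups on the ring serve as well.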